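Trading a Trifluoromethyl Group for Bromo on the Ring

The source may hold more compounds than are shown below. What is called first, only, known or untested is meant among the compounds shown, and "the series" means these compounds.

Of the compounds shown here, three built on one shared core have been measured in a functional assay on the whole organism with Mus musculus as the target; a higher number here means that more compound is needed for the effect, a lower number that less compound is needed. Compound 1 `FC(F)(F)c1cccc(-n2nncc2-c2ccncc2)c1` gives 44.7 mg/kg. Compound 2 `c1ccc(-n2nncc2-c2cccnc2)cc1` gives 39.7 mg/kg, and compound 3 `FC(F)(F)c1ccc(-n2nncc2-c2cccnc2)cc1` gives 90.5 mg/kg. Compound 3 thus stands highest of the three numbers; its gaps to compound 1 and to compound 2 are both beyond the usual scatter, so more of compound 3 is needed for the same effect than of either of the others. For the measured compounds named here, the only step between measured compounds that differ in a single place is a 2.3-fold higher number from compound 2 to compound 3 (0.36 log units; beyond the scatter), where a trifluoromethyl group takes the place of a hydrogen on an aromatic carbon.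

Compound 4 `Brc1ccc(-n2nncc2-c2cccnc2)cc1` has not yet been measured. Compared with compound 3 the change is bromo in place of trifluoromethyl on an aromatic carbon. Going by the values given here, no measured pair shows this exact swap. The step from compound 2 to compound 3 bears on it indirectly: introducing the trifluoromethyl group that now leaves went with a higher number. Compound 4 is therefore expected to land somewhere between the numbers of compound 2 and compound 3. The expected step is a 1.5-fold lower number from compound 3 to compound 4 (0.18 log units; within the scatter), toward a lower number but close to the scatter. For compound 4 the estimate in this assay is 60 mg/kg, with a range from 30 mg/kg to 120 mg/kg.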

Compound 4, dose for half-maximal effect: 40.7 mg/kg
Compound 4: middle estimate off by 1.5-fold (0.17 log units), on the high side; the range from low to high includes it.
By their numbers in this assay, from the lowest: compounds 2, 4 and 1 (each within the scatter of the next); then compound 3.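

At this place, on an aromatic carbon para to a large group, bromo in place of trifluoromethyl gives a 2.2-fold lower number from compound 3 to compound 4 (0.35 log units; beyond the scatter) in this assay, so the higher number of compound 3 does not carry over to every group put here. Measured against the unsubstituted compound, bromo gives a 1.0-fold higher number from compound 2 to compound 4 (0.01 log units; within the scatter), which means that compound 2 and compound 4 cannot be told apart, while the trifluoromethyl group alone stands apart from hydrogen with a 2.3-fold higher number from compound 2 to compound 3 (0.36 log units; beyond the scatter). Nothing available here explains why bromo and trifluoromethyl part ways at this carbon.

The compounds shown put only hydrogen, bromo and trifluoromethyl at this place, so it stays open how an amine, a carboxylic acid or a longer chain would read there in this assay. For the compounds shown here, it also stays open whether bromo on another aromatic carbon of this ring would match compound 4, since no compound here makes that single change.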